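A few compounds are considered here, and "the series" means these few. Any claim that something is new, unique, unknown or untested is made for them only; others in the source may bear on it.

Compound 1 `Cc1cccc(Nc2nccc(-c3cccs3)n2)c1`: in a functional assay for inhibition, with Homo sapiens as the target (a lower number here means a stronger inhibitor, a higher number a weaker inhibitor), compound 1 gives 300 nM.
Compound 2 `Cc1ccc(-c2ccnc(Nc3cccc(N(C)C)c3)n2)s1`: compound 2 gives 5700 nM.
Compound 3 `c1coc(-c2ccnc(Nc3ccc(-n4ccnc4)cc3)n2)c1`: compound 3 gives 2200 nM.

Among these three numbers compound 3 stands second highest. Its nearest neighbour is compound 2, which lies beyond the scatter above it, while compound 1 lies furthest away, well below it. Compound 4 `CN(C)c1ccc(Nc2nccc(-c3ccco3)n2)cc1` differs from compound 3 in one place: dimethylamino in place of 1H-imidazol-1-yl on an aromatic carbon. Within the data shown here, no two measured compounds differ in a single place, so no measured step guides this change. Compound 2 also carries a dimethylamino and gives 5700 nM in this assay. On that basis a modest weakening is expected, a 1.4-fold higher number from compound 3 to compound 4 (0.13 log units; within the scatter), though it may well stay within the scatter. Compound 4 is therefore estimated at 3000 nM, with a range from 1000 nM to 9000 nM.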

Compound 4, half-maximal inhibitory concentration: 1900 nM
Compound 4: middle estimate off by 1.6-fold (0.20 log units), on the high side, within the range that was stated.
By their numbers in this assay, from the lowest: compound 1; then compounds 4 and 3 (each within the scatter of the next); then compound 2.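

In this assay, replacing 1H-imidazol-1-yl with dimethylamino on this aromatic carbon, para to a large group, gives a 1.2-fold lower number from compound 3 to compound 4 (0.06 log units; within the scatter). This first single-place step shows that the five-membered aromatic ring can give way to a group with no ring and no change beyond the scatter. No measured evidence accounts for this result. On these data alone, a carboxylic acid or a primary amine on this carbon remains open. So does whether the same exchange would behave alike on the core of compound 1.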